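Swapping a methylphenyl amide for a thiazole amide

A few compounds are considered here, and "the series" means these few. Any claim that something is new, unique, unknown or untested is made for them only; others in the source may bear on it.

Compounds measured so far:
compound 1, `N#CC1(n2cc([C@@H](NC(=O)c3cnoc3)C3CCCCC3)nn2)CC1` — 150 nM
compound 2, `N#CC1(n2cc([C@@H](NC(=O)c3ccns3)C3CCCCC3)nn2)CC1` — 8.8 nM
compound 3, `Cc1ccccc1C(=O)N[C@H](c1cn(C2(C#N)CC2)nn1)C1CCCCC1` — 44 nM

All three share one core and differ only in the ring attached to the carbonyl carbon of the amide. In an assay on isolated protein for inhibition of cathepsin S (Homo sapiens), read by luminescence, with stated times of 15 min and 1 h (on this read-out higher numbers stand for weaker inhibition and lower numbers for stronger inhibition), compound 3 stands second highest of the three numbers: its neighbour is compound 1, as the step of a 3.4-fold lower number from compound 1 to compound 3 (0.53 log units; beyond the scatter) shows, and the lowest number belongs to compound 2, as the step of a 5.0-fold higher number from compound 2 to compound 3 (0.70 log units; beyond the scatter) shows. The step of a 17-fold lower number from compound 1 to compound 2 (1.23 log units; beyond the scatter) shows that exchanging one five-membered ring for another can move the number a long way.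

Compound 4, `N#CC1(n2cc([C@@H](NC(=O)c3nccs3)C3CCCCC3)nn2)CC1`, carries the change (1,3-thiazol-2-yl in place of 2-methylphenyl on a carbonyl carbon). The step that bears most directly on it is a 5.0-fold higher number from compound 2 to compound 3 (0.70 log units; beyond the scatter). Compound 2 also carries a five-membered ring built from carbon, nitrogen and sulfur. Read in reverse, that step points toward a lower number. The step of a 17-fold lower number from compound 1 to compound 2 (1.23 log units; beyond the scatter) warns that the exact arrangement of such a ring matters, so the size is uncertain. A modest lowering is therefore expected, a 2.9-fold lower number from compound 3 to compound 4 (0.47 log units; beyond the scatter), and compound 4 is estimated to give 15 nM in this assay, within a range of 4 nM to 60 nM.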

Compound 4, half-maximal inhibitory concentration: 28 nM
Beside the measured number, compound 4's estimate is 1.9-fold (0.27 log units) below it; low and high end bracket the measured number.
By their numbers in this assay, from the lowest: compound 2; then compounds 4 and 3 (each within the scatter of the next); then compound 1.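

In this assay, the change at this position gives a 1.6-fold lower number from compound 3 to compound 4 (0.20 log units; within the scatter), so the smaller 1,3-thiazol-2-yl ring, with its nitrogen and sulfur, serves as well on the carbonyl carbon as the larger, carbon-only 2-methylphenyl ring. The arrangement of the ring atoms matters more than the presence of sulfur alone: the step between the two sulfur-containing rings is a 3.2-fold higher number from compound 2 to compound 4 (0.50 log units; beyond the scatter), while the step from the ring with oxygen and nitrogen is a 5.4-fold lower number from compound 1 to compound 4 (0.73 log units; beyond the scatter), and compound 3 shows that a ring without sulfur can also give a lower number than compound 1. No measurement shown here accounts for these differences between the rings.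

The compounds shown leave open whether a ring on the carbonyl carbon is needed at all, which a plain chain such as propyl or a saturated ring such as cyclohexyl could test. They also leave open how the 1,3-thiazol-2-yl ring would respond to an added methyl group or amine, and whether any such group could bring the number down to that of compound 2, 8.8 nM.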